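The compounds below may be only part of what the source reports. "The series", "measured", "known", "first", "only" and "open" are said of these compounds alone.

In a functional assay on NCI-H1993 cells (Homo sapiens) for inhibition, read by CCK-8 assay, with a stated time of 72 h (a higher number here means a weaker inhibitor, a lower number a stronger inhibitor), compound 2 `COC(=O)c1ccc(-c2cnc3ncn(C(C)c4c(F)cc5ncccc5c4F)c3n2)cc1F` gives 29.4 nM, the lowest of the two numbers seen so far; compound 1 `CC(c1c(F)cc2ncccc2c1F)n1cnc2ncc(-c3ccccc3)nc21` gives 514 nM. Among the compounds with values here, the one measured step, a 17-fold lower number from compound 1 to compound 2 (1.24 log units; beyond the scatter), shows that the group on that aromatic carbon matters. Compound 3 `CC(c1c(F)cc2ncccc2c1F)n1cnc2ncc(-c3cnc4ccccc4c3)nc21` carries quinolin-3-yl in place of 3-fluoro-4-(methoxycarbonyl)phenyl on an aromatic carbon. Within the data shown here, no measured step covers a quinolin-3-yl at this place, so the step from compound 1 to compound 2 is only an indirect guide. Compound 3 is therefore expected to lose some potency, by about a 3.4-fold higher number from compound 2 to compound 3 (0.53 log units; beyond the scatter), landing at an estimated 100 nM, within a range of 20 nM to 600 nM.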

Compound 3, half-maximal inhibitory concentration: 46.1 nM
Compound 3: the middle estimate sits 2.2-fold (0.34 log units) above what was measured; the range from low to high includes it.
By their numbers in this assay, from the lowest: compounds 2 and 3 (each within the scatter of the next); then compound 1.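

In this assay the swap of 3-fluoro-4-(methoxycarbonyl)phenyl for quinolin-3-yl gives a 1.6-fold higher number from compound 2 to compound 3 (0.20 log units; within the scatter) and so leaves the two groups level at this place. Measured against phenyl, quinolin-3-yl gives an 11-fold lower number from compound 1 to compound 3 (1.05 log units; beyond the scatter) in the same direction as the earlier gain, so that gain does not depend on a methoxycarbonyl or a fluorine. No available measurement bears on why these two different groups match. Still open, from the compounds shown here alone, is whether a pyridin-3-yl would hold this level, and whether a carboxylic acid or an amide could replace the methyl ester.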